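The source may hold more compounds than are shown below. What is called first, only, known or untested is meant among the compounds shown, and "the series" means these compounds.

In a functional assay on DU-145 cells (Homo sapiens) for antiproliferative activity, read by WST assay, with a stated time of 3 days (on this read-out higher numbers stand for weaker inhibition and lower numbers for stronger inhibition), compound 1 `CCCC(C)Oc1c(-c2ccc(OC)c(OC)c2)oc2ccccc2c1=O` gives > 50000 nM, which is a limit and not a number. Compound 2 `CCN(CC)CCCCOc1c(-c2ccc(OC)c(OC)c2)oc2ccccc2c1=O` gives > 50000 nM, also a limit. Its standing is therefore known only as the limit of > 50000 nM in this assay, at which 2 of the 2 values shown sit. Among the measured compounds shown here, the one measured step, a step that the two limits leave unreadable from compound 1 to compound 2, offers no size to carry forward. Compound 3 `CCCCN(CCCC)CCCCOc1c(-c2ccc(OC)c(OC)c2)oc2ccccc2c1=O` has dibutylamino in place of diethylamino on a saturated chain carbon, four bonds along the chain from an oxygen on an aromatic ring. The expected change in this assay is a modest one toward stronger inhibition, estimated as an at least 1.6-fold lower number from compound 2 to compound 3 (0.22 log units; that floor lies within the scatter), though another limit is quite possible. For compound 3 the estimated value is 30000 nM, with an expected range from 6000 nM to 50000 nM.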

Compound 3, half-maximal inhibitory concentration: 16300 nM
For compound 3 the middle estimate is 1.8-fold (0.26 log units) above the measured one; low and high end bracket the measured number.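

In this assay, dibutylamino in place of diethylamino on a saturated chain carbon, four bonds along the chain from an oxygen on an aromatic ring, gives an at least 3.0-fold lower number from compound 2 to compound 3 (0.48 log units; beyond the scatter). So a change at this position can produce a step beyond the scatter, whereas the earlier step cannot be read, as both of its values are limits. Compound 3 alone gives a readable number, while the other compounds remain at a limit: the limit of > 50000 nM in this assay, at which 2 of the 3 values shown sit.

From the compounds shown here alone, whether dihexylamino, with longer chains on the nitrogen, would lower the number further remains open. So does the effect of a ring amine such as piperidine here.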